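The compounds below may be only part of what the source reports. "The series", "measured", "known", "first", "only" and "open" are said of these compounds alone.

Of the compounds shown here, three built on one shared core have been tested in a functional assay on HeLa cells (Homo sapiens) for cytotoxicity, read by cell counting, with a stated time of 48 h; on this read-out higher numbers stand for an effect only at larger amounts of compound and lower numbers for an effect already at smaller amounts. Compound 1 `CCCCCCCCCCCCCCCCCCCCCC(=O)O[C@H]1[C@H](O)[C@H](n2ccc(N)nc2=O)O[C@@H]1CO` gives 1.1 ug/mL. Compound 2 `CCCCCCCC(=O)O[C@H]1[C@H](O)[C@H](n2ccc(N)nc2=O)O[C@@H]1CO` gives 0.1 ug/mL in this assay. Compound 3 `CCCCCCCCCCCC(=O)O[C@H]1[C@H](O)[C@H](n2ccc(N)nc2=O)O[C@@H]1CO` gives 0.08 ug/mL in this assay, the lowest of the three numbers, although its gap to compound 2 lies within the scatter, so these two cannot be told apart. The measured steps concern the chain: a 14-fold lower number from compound 1 to compound 3 (1.14 log units; beyond the scatter) is a large step, whereas a 1.3-fold lower number from compound 2 to compound 3 (0.10 log units; within the scatter) stays within the scatter.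

Compound 4 `CC(=O)O[C@H]1[C@H](O)[C@H](n2ccc(N)nc2=O)O[C@@H]1CO` is not yet measured. It differs from compound 3 in one place: hydrogen in place of decyl on a saturated chain carbon bound to a carbonyl carbon. Both earlier steps bear on this change, as each also swaps hydrogen and a part of the chain. Putting hydrogen in place of decyl, from compound 1 to compound 3, lowered the number sharply, but adding butyl, from compound 2 to compound 3, changed little. The change to compound 4 removes decyl from a point bound to the carbonyl carbon, closer than either measured step, so a move beyond the scatter in either direction stays possible, while the flat comparison of compound 2 with compound 3 points to a number near that of compound 3. Compound 4 is therefore estimated to give 0.3 ug/mL in this assay, within 0.06 ug/mL to 1.5 ug/mL. This estimate means an expected step of a 3.8-fold higher number from compound 3 to compound 4 (0.57 log units; beyond the scatter).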

Compound 4, concentration for half-maximal effect: 0.14 ug/mL
Estimate against measurement, compound 4: 2.1-fold (0.33 log units) above; the range from low to high includes it.
By their numbers in this assay, from the lowest: compounds 3, 2 and 4 (each within the scatter of the next); then compound 1.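

In this assay, hydrogen in place of decyl on a saturated chain carbon bound to a carbonyl carbon gives a 1.8-fold higher number from compound 3 to compound 4 (0.24 log units; within the scatter), and hydrogen in place of hexyl at that same place gives a 1.4-fold higher number from compound 2 to compound 4 (0.15 log units; within the scatter). Both steps stay within the scatter, so the stretch of chains that cannot be told apart, which earlier covered only compound 2 and compound 3, now also takes in compound 4, whose chain ends in hydrogen at this position. Compound 1 goes against this flat picture, since its longer chain stands apart with a 14-fold lower number from compound 1 to compound 3 (1.14 log units; beyond the scatter), so the chain matters in this assay only at the long end of the compounds shown.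

Still open, going by these compounds, are whether an amine or a carboxylic acid on this chain carbon would stay with compound 3 and compound 4, and whether a chain of a length between those of compound 3 and compound 1 would follow compound 3 or compound 1. Nothing among the data given explains why these chains behave as they do in the cell assay.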